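The source may hold more compounds than are shown below. What is called first, only, known or untested is meant among the compounds shown, and "the series" means these compounds.

Of the compounds shown here, three have been tested in an ADME assay on cells (Peritoneal macrophage cell, Mus musculus) for cytotoxicity, read by fluorescence and resazurin assay, with a stated time of 3 days (a higher number here means that more compound is tolerated, a lower number that less compound is tolerated), and none gave a number. Compound 1 (`O=C(Nc1[nH]nc(-c2ccccn2)c1C1CC1)c1ccccc1F`) returned > 64000 nM, which is a limit of the assay and not a measured value. Compound 2 (`O=C(Nc1cc(-c2ccccn2)n[nH]1)N1CCN(c2ccc(F)cc2)CC1`) returned > 57000 nM, also a limit. Compound 3 (`O=C(Nc1cc(-c2ccccn2)n[nH]1)N1CCC(c2ccc(F)cc2)CC1`) returned > 64000 nM, again a limit. Compound 1 therefore stands at the limit of > 64000 nM in this assay, at which 2 of the 3 values shown sit, while compound 2 stands at the limit of > 57000 nM in this assay, at which 1 of the 3 values shown sits.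

Compound 4 (`COc1ccccc1C(=O)Nc1[nH]nc(-c2ccccn2)c1C1CC1`) keeps the core of compound 1 and carries methoxy in place of fluoro on an aromatic carbon, ortho to a large group: methoxy in place of fluoro on an aromatic carbon. Within the data shown here, no measured pair of compounds shows what a single change does in this assay. The expectation therefore rests on compound 1 at > 64000 nM, and no step beyond the usual scatter is expected, with the assay quite likely to report only a limit again.

The estimate amounts to an expected at least 1.0-fold lower number from compound 1 to compound 4 (0.02 log units; that floor lies within the scatter). For compound 4 the estimated value is 60000 nM, with an expected range from 25000 nM to 100000 nM.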

Compound 4, half-maximal cytotoxic concentration: > 51000 nM
Compound 4: a limit, no number (the forecaster's own chance of this, stated with the estimate: 70%); the middle value is on the limit's open side.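

In this assay compound 4 returned > 51000 nM, a limit of the assay; compound 1 also gave only a limit, so no step can be read between compound 1 and compound 4. The compounds shown leave open what methoxy in place of fluoro does in this assay.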